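Swapping fluoro for hydroxy on the aniline of compound 1

The compounds below may be only part of what the source reports. "The series", "measured", "known", "first", "only" and "open" are said of these compounds alone.

Going by the values given here, compound 1 `C=C1[C@@H](OC(C)=O)C[C@@H]2[C@](C)(CO[Si](C)(C)C(C)(C)C)[C@H](OC(C)=O)CC[C@@]2(C)[C@@H]1C[C@@H](Nc1ccc(F)cc1)C1=CCOC1=O` is one of two compounds measured in a functional assay on A549 cells (Homo sapiens) for cytotoxicity, read by sulforhodamine B assay; on this read-out higher numbers stand for weaker inhibition and lower numbers for stronger inhibition; in this assay compound 1 gives 4550 nM, the lower of the two numbers. Its companion, compound 2 `C=C1[C@@H](OC(C)=O)C[C@@H]2[C@](C)(COC=O)[C@H](OC(C)=O)CC[C@@]2(C)[C@@H]1C[C@@H](Nc1ccc(F)cc1)C1=CCOC1=O`, differs only in a group on an oxygen on a saturated carbon and gives 21300 nM in this assay; that change produced a 4.7-fold higher number from compound 1 to compound 2 (0.67 log units; beyond the scatter). The unmeasured compound 3 `C=C1[C@@H](OC(C)=O)C[C@@H]2[C@](C)(CO[Si](C)(C)C(C)(C)C)[C@H](OC(C)=O)CC[C@@]2(C)[C@@H]1C[C@@H](Nc1ccc(O)cc1)C1=CCOC1=O` keeps everything in compound 1 except one spot: hydroxy in place of fluoro on an aromatic carbon. Among the compounds with values here, no measured step touches this part of the molecule; the single measured step concerns a group on an oxygen on a saturated carbon, far from the aromatic ring, so it offers no guide here. With nothing arguing for a shift in either direction, the expected change is a 1.1-fold higher number from compound 1 to compound 3 (0.04 log units; within the scatter), a step that stays within the scatter. Compound 3 is therefore estimated at 5000 nM, within a range from 1500 nM to 16000 nM.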

Compound 3, half-maximal inhibitory concentration: 5090 nM
For compound 3 the middle estimate is 1.0-fold (0.01 log units) below the measured one; the measured number falls inside the stated range.
By their numbers in this assay, from the lowest: compounds 1 and 3 (each within the scatter of the next); then compound 2.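

In this assay, going by these compounds alone, the first measured change on this aromatic ring, 4-fluorophenyl to 4-hydroxyphenyl, gives a 1.1-fold higher number from compound 1 to compound 3 (0.05 log units; within the scatter). The step therefore separates this position from the group on the oxygen on a saturated carbon, where the step from compound 1 to compound 2 lies beyond the scatter. Hydroxy brings a hydrogen-bond donor and a hydrogen-bond acceptor that fluoro does not count, yet compound 1 and compound 3 cannot be told apart on this read-out, and no measurement available here accounts for this.

As far as these compounds go, whether a group such as an amine, a carboxylic acid or a longer chain at the same ring position would also leave the number in place remains open. Also open, from the compounds shown here alone, is whether the hydroxy for fluoro exchange would read the same on the background of compound 2.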